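The source may report more compounds than this note shows. Statements on the series, on what has been measured and on what is new or still open speak of the compounds shown alone.

Compound 1, `CCC(c1ccccc1)c1nc(-c2ccc(Cl)cc2)c(CC(=O)O)s1`: 190 nM
Compound 2, `COc1cc(-c2nc(C(c3ccc(F)cc3)c3ccc(F)cc3)sc2CC(=O)O)ccn1`: 29 nM

Going by the values given here, of the two numbers measured so far, compound 1 holds the higher one. Among the compounds with values here, in an in vitro assay on HEK385-7 cells for displacement of a labelled ligand from prostaglandin D2 receptor 2 (Homo sapiens) (on this read-out lower numbers stand for stronger inhibition and higher numbers for weaker inhibition), compound 1 gives 190 nM, and compound 2 gives 29 nM; no step between these two compounds is worked out here, since they differ in more than one place, and their two values alone show that the gap between them lies beyond the usual scatter.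

The compound still to be measured is compound 3, `O=C(O)Cc1sc(C(c2ccccc2)c2ccccn2)nc1-c1ccc(Cl)cc1`. Compared with compound 1 it carries one change, (pyridin-2-yl in place of ethyl on a saturated chain carbon bound to two aromatic carbons). Compound 3 thus has two aromatic rings on that saturated chain carbon, as compound 2 does.

The step from compound 1 to compound 3 is expected to run downward, toward a lower number and beyond the scatter, as a 3.2-fold lower number from compound 1 to compound 3 (0.50 log units; beyond the scatter). That expectation rests on the fact that compound 2 gives 29 nM while carrying two aromatic rings on the same kind of saturated chain carbon. Compound 3 is therefore estimated to give 60 nM, with a likely range from 20 nM to 200 nM.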

Compound 3, half-maximal inhibitory concentration: 810 nM
Estimate against measurement, compound 3: 14-fold (1.13 log units) below; the whole stated range lies below it.
By their numbers in this assay, from the lowest: compound 2; then compound 1; then compound 3.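

In this assay, going by these compounds alone, pyridin-2-yl in place of ethyl on a saturated chain carbon bound to two aromatic carbons gives a 4.3-fold higher number from compound 1 to compound 3 (0.63 log units; beyond the scatter), the first step that can be read at this position. It shows that this position responds to the exchange of ethyl for pyridin-2-yl, and that here a second aromatic ring on that carbon does not by itself bring a lower number, so the low value of compound 2 cannot be credited to such a ring alone. Nothing at hand accounts for the direction or the size of this step.

The compounds shown leave open whether the rise belongs to aromatic rings on that carbon in general or to pyridin-2-yl in particular, since a phenyl, a pyridin-3-yl or a pyridin-4-yl in the same place would separate those readings, and a propyl would show how a longer chain fares there. They also leave open whether the same change would run the same way with the other parts of the molecule altered, as they are in compound 2.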